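The source may hold more compounds than are shown below. What is called first, only, known or untested is meant among the compounds shown, and "the series" means these compounds.

Measured so far:
- compound 1 `CCOC(=O)Cc1nc(N)n(C(=O)c2ccccc2)n1`: 57.5% in a functional assay on the whole organism (strain albino) for inhibition, with Rattus norvegicus as the target, read by paw edema, with stated times of 30 min and 3 h, at a dose of 5 mg/kg by the oral route; a higher number here means more inhibition at the dose given (going by the name of the read-out), a lower number less inhibition
- compound 2 `CCOC(=O)Cc1nc(N)n(C(=O)c2ccc(Cl)cc2)n1`: 62.8%
- compound 3 `CCOC(=O)Cc1n[nH]c(NC(=O)c2ccccc2)n1`: 55.3%

Compound 3 holds the lowest of the three numbers, but the gaps to compound 1 and to compound 2 are both within the scatter, so the three cannot be ordered on these data.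

Compound 4 `CCOC(=O)Cc1n[nH]c(NC(=O)c2ccc(Cl)cc2)n1` differs from compound 3 by chloro in place of hydrogen on an aromatic carbon. Among the measured compounds shown here, the only measured step of this kind is a number 5.3 percentage points higher from compound 1 to compound 2 (within the scatter), which stays within the scatter. On that basis the change from compound 3 to compound 4 is expected to give a step of about the same size in this assay, upward if anything, but not beyond the scatter; the expected step is a number 4.7 percentage points higher from compound 3 to compound 4 (within the scatter). Compound 4 is therefore estimated at 60%, with a range from 50% to 70%.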

Compound 4, a percentage reported as inhibition, in the whole organism at one dose (the size of the read-out at that dose, not a potency): 58.5%
The estimate for compound 4 lay 1.5 percentage points above the measured number, and the stated range covers the measured number.
By their numbers in this assay, from the lowest: compounds 3, 1, 4 and 2 (each within the scatter of the next).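

The phenyl to 4-chlorophenyl change now appears on a second core, and in this assay it gives a number 3.2 percentage points higher from compound 3 to compound 4 (within the scatter). The two steps for this change agree across the cores: the same change on two cores in this assay, a number 5.3 percentage points higher (within the scatter) from compound 1 to compound 2 and a number 3.2 percentage points higher (within the scatter) from compound 3 to compound 4, 2.1 percentage points apart, within the scatter of two such steps Neither step leaves the scatter, so on these two cores chloro on the aromatic carbon para to a large group has no effect that can be separated from it.

Open, from the compounds shown here alone, is whether another group at this place, such as an amine or a carboxylic acid, would move the number beyond the scatter. Also open, going by these compounds, is what a carboxylic acid in place of the ethyl ester would give.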